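Moving a trifluoromethyl group and what it may change

This account rests on a few compounds, and the source may have more. Where it says the series, first, only, none or still open, it means among the compounds named here.

Four compounds share a core in which a sulfur links a chain to a phenyl ring that carries a trifluoromethyl group. Compound 1 `CC(O)(CSc1ccc(C(F)(F)F)cc1)C(=O)Nc1ccc(S(F)(F)(F)(F)F)cc1` and compound 2 `CC(O)(CSc1cccc(C(F)(F)F)c1)C(=O)Nc1ccc(S(F)(F)(F)(F)F)cc1` have one core; compound 3 `CC(O)(CSc1ccc(C(F)(F)F)cc1)C(=O)Nc1cccc(S(F)(F)(F)(F)F)c1` and compound 4 `CC(O)(CSc1cccc(C(F)(F)F)c1)C(=O)Nc1cccc(S(F)(F)(F)(F)F)c1` have another, and the difference between the two cores is not broken down here. All were tested in a functional assay on VCaP cells (Homo sapiens) for antiproliferative activity, read by propidium iodide staining, with a stated time of 96 h; a lower number here means a stronger inhibitor, a higher number a weaker inhibitor. Compound 1 gives 24800 nM, compound 2 gives 18800 nM, and compound 3 gives 27300 nM. The change from compound 1 to compound 2 is 3-(trifluoromethyl)phenyl in place of 4-(trifluoromethyl)phenyl on a sulfur, and it gave a 1.3-fold lower number from compound 1 to compound 2 (0.12 log units; within the scatter). The change from compound 3 to compound 4 is the same change: 3-(trifluoromethyl)phenyl in place of 4-(trifluoromethyl)phenyl on a sulfur.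

Compound 4 has not been measured. The step from compound 3 to compound 4 is expected to be about a 1.2-fold lower number from compound 3 to compound 4 (0.09 log units; within the scatter), resting on the step from compound 1 to compound 2, which gave a 1.3-fold lower number from compound 1 to compound 2 (0.12 log units; within the scatter). Compound 4 is therefore estimated to give about 22000 nM in this assay, with a likely range from 11000 nM to 45000 nM.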

Compound 4, half-maximal inhibitory concentration: 20200 nM
Compound 4: middle estimate off by 1.1-fold (0.04 log units), on the high side; the range from low to high includes it.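

In this assay, 3-(trifluoromethyl)phenyl in place of 4-(trifluoromethyl)phenyl on a sulfur gave a 1.4-fold lower number from compound 3 to compound 4 (0.13 log units; within the scatter). Set beside the earlier result, the same change reads alike on the two cores: the same change on two cores in this assay, a 1.3-fold lower number (0.12 log units; within the scatter) from compound 1 to compound 2 and a 1.4-fold lower number (0.13 log units; within the scatter) from compound 3 to compound 4, 1.0-fold (0.01 log units) apart, within the scatter of two such steps. Because each step is itself within the scatter, what carries from one core to the other is only the lack of a clear effect, and these results do not show that the change makes a stronger inhibitor on either core, nor that the same would hold on cores beyond these two.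

The compounds shown leave open whether this change would stay as small on a core that differs in some other way, since only two cores are compared here. They also leave open what a nitrile, an amine or a carboxylic acid in place of the trifluoromethyl group would give in this assay, and whether any such group would produce a step that stands clear of the scatter.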